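The compounds below may be only part of what the source reports. "The series", "measured", "known", "first", "only" and "open" are said of these compounds alone.

In an ADME assay on the whole organism (Rattus norvegicus) for pharmacokinetics, using cassette dosing, at a dose of 1 mg/kg by the oral route (on this read-out lower numbers stand for lower oral bioavailability and higher numbers for higher oral bioavailability), compound 1 (`C[C@@H](Cn1c(=O)[nH]/c(=N\c2ccc(Oc3cncc(F)c3)cc2)n(Cc2ccc(Cl)cc2)c1=O)C(=O)O`) gives 74.3%, the higher of the two numbers at hand. Compound 2 (`CC(C)Oc1ccc(Nc2nc(=O)n(CCO)c(=O)n2Cc2ccc(Cl)cc2)cc1Cl`) gives 48.1%, a gap beyond the usual scatter. Compound 3 (`C[C@@H](Cn1c(=O)[nH]/c(=N\c2ccc(Oc3ccnc(F)c3)cc2)n(Cc2ccc(Cl)cc2)c1=O)C(=O)O`) keeps the core of compound 1 but carries 2-fluoropyridin-4-yl in place of 5-fluoropyridin-3-yl on an oxygen on an aromatic ring. For the measured compounds named here, no measured pair shows what such a swap does in this assay, so no change beyond the scatter is expected in either direction. The estimated step is a number 8.3 percentage points lower from compound 1 to compound 3 (within the scatter). For compound 3 the expected value is 66%, within an estimated range of 43% to 86%.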

Compound 3, oral bioavailability: 43.2%
Compound 3: the middle estimate sits 22.8 percentage points above what was measured, within the range that was stated.
By their numbers in this assay, from the lowest: compounds 3 and 2 (each within the scatter of the next); then compound 1.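

In this assay, putting 2-fluoropyridin-4-yl in place of 5-fluoropyridin-3-yl on an oxygen on an aromatic ring gives a number 31.1 percentage points lower from compound 1 to compound 3 (beyond the scatter). The two groups hold the same atoms, joined differently, so at this position the arrangement within the ring alone is enough to move the read-out beyond the scatter. Nothing at hand accounts for this drop. Still open, as far as these compounds go, is how a plain phenyl or an unfluorinated pyridin-3-yl would read on this oxygen, and whether the same swap would give a similar step on another core.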